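A few compounds are considered here, and "the series" means these few. Any claim that something is new, unique, unknown or untested is made for them only; others in the source may bear on it.

Measured compounds:
- compound 1, `O=C(CN(C(=O)c1ccc(Cl)cc1)C1CCCCC1)Nc1cc(F)cc(F)c1`, 631 nM
- compound 2, `O=C(CN(C(=O)c1ccc(-c2ccccn2)cc1)C1CCCCC1)Nc1cc(F)cc(F)c1`, 63.1 nM

Both compounds were tested in an assay on HEK293 cells for inhibition of sodium- and chloride-dependent glycine transporter 1 (Homo sapiens), read by scintillation proximity assay; on this read-out higher numbers stand for weaker inhibition and lower numbers for stronger inhibition. Compound 1 gives 631 nM. Among the compounds with values here, compound 2 gives 63.1 nM and so has the lower of the two numbers in this assay, the only measured change being a 10-fold lower number from compound 1 to compound 2 (1.00 log units; beyond the scatter), which comes from pyridin-2-yl in place of chloro on an aromatic carbon.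

Compound 3, `O=C(CN(CC1CCC1)C(=O)c1ccc(-c2ccccn2)cc1)Nc1cc(F)cc(F)c1`, has not yet been measured. It differs from compound 2 by cyclobutylmethyl in place of cyclohexyl on an amide-type nitrogen. Within the data shown here, no measured step touches the amide-type nitrogen: the single measured step, a 10-fold lower number from compound 1 to compound 2 (1.00 log units; beyond the scatter), concerns the aromatic ring on the other side of the core and offers no guide to a change on the nitrogen. With nothing to go on beyond the structural change itself, the step from compound 2 to compound 3 is expected to be small, at most a modest rise in the number, and the estimated size is a 1.6-fold higher number from compound 2 to compound 3 (0.20 log units; within the scatter). Compound 3 is therefore estimated at 100 nM in this assay, with a range from 30 nM to 400 nM.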

Compound 3, half-maximal inhibitory concentration: 126 nM
Beside the measured number, compound 3's estimate is 1.3-fold (0.10 log units) below it; the measured number falls inside the stated range.
By their numbers in this assay, from the lowest: compounds 2 and 3 (each within the scatter of the next); then compound 1.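

Within the data shown here, compound 3 gives the first reading at the amide-type nitrogen: in this assay, the change from cyclohexyl to cyclobutylmethyl gives a 2.0-fold higher number from compound 2 to compound 3 (0.30 log units; within the scatter). The numbers of the two compounds therefore cannot be told apart, even though a six-membered non-aromatic ring on the nitrogen gives way to a four-membered one attached through a saturated chain carbon, whereas the earlier step spoke only of the aromatic ring on the other side of the core. No supporting data accompany this result that could say why the two groups read alike at this nitrogen.

The compounds shown leave open how the number responds when the group on this nitrogen carries an amine or a hydroxyl, or is a phenyl ring or a simple methyl, as both groups seen here are made of carbon only and have no hydrogen-bond donors or acceptors. They also leave open whether cyclobutylmethyl would read the same way alongside the chloro group of compound 1 as it does alongside pyridin-2-yl.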